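The compounds below may be only part of what the source reports. "The series", "measured", "known", "first", "only" and "open" are said of these compounds alone.

Among the measured compounds shown here, compound 1 `CCc1cccc2c(O)c(-c3occ(C)c3C(=O)O)ccc12` and compound 2 `CCOC(=O)c1c(C)coc1-c1ccc2c(CC)cccc2c1OC` are the two measured members so far. In a functional assay on ZR-75-1 cells (Homo sapiens) for cytotoxicity, read by MTT assay, with a stated time of 72 h (on this read-out lower numbers stand for an effect already at smaller amounts and higher numbers for an effect only at larger amounts of compound), compound 1 gives 0.3 ug/mL. In this assay compound 2 gives 3.9 ug/mL, the higher of the two numbers, with compound 1 well below it. Compound 3 `CCc1cccc2c(OC)c(-c3occ(C)c3C(=O)NC)ccc12` is not yet measured; it differs from compound 2 by methylamino in place of ethoxy on a carbonyl carbon. No comparable change between measured compounds is available to lean on, so the step is expected to be small, a 1.3-fold lower number from compound 2 to compound 3 (0.11 log units; within the scatter), and not beyond the scatter. Compound 3 is estimated at 3 ug/mL, with a range from 0.8 ug/mL to 12 ug/mL.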

Compound 3, concentration for half-maximal effect: > 10 ug/mL
Compound 3: no number, only a limit; the forecaster's own chance of this, stated with the estimate: 5%; at least 3.3-fold (0.52 log units) between middle value and limit.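

At the carbonyl carbon, methylamino in place of ethoxy gives an at least 2.5-fold higher number from compound 2 to compound 3 (0.40 log units; beyond the scatter) in this assay. Among the compounds shown here, this is the first change in a single place, and it shows that the read-out responds to what sits on this carbonyl carbon, which the earlier pair, differing in more than one place, could not show. Compound 3 carries no number, only a limit: the limit of > 10 ug/mL in this assay, at which 1 of the 3 values shown sits.

On these data alone, the true size of the step stays open. Also open, as far as these compounds go, is how dimethylamino, or a longer chain on the nitrogen, would read at this carbon.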